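A few compounds are considered here, and "the series" means these few. Any claim that something is new, unique, unknown or untested is made for them only; others in the source may bear on it.

Measured so far in a functional assay on KYSE-70 cells for antiproliferative activity against KYSE-70 cell line (Homo sapiens), read by MTT assay, with a stated time of 72 h; on this read-out lower numbers stand for stronger inhibition and higher numbers for weaker inhibition:
- Compound 1 `COc1ccc(OC)c(NC(=O)c2cc(=O)[nH]c3cc(Br)ccc23)c1`: > 20000 nM (a limit of the assay)
- Compound 2 `O=C(Nc1cccc(OC(F)(F)F)c1)c1cc(=O)[nH]c2cc(Br)ccc12`: > 20000 nM (a limit of the assay)
- Compound 3 `O=C(Nc1cccc(F)c1)c1cc(=O)[nH]c2cc(-c3cccc(F)c3)ccc12`: 12000 nM

Compound 3 is the only one of the three with an actual number, 12000 nM. The other two results are limits and not numbers: the limit of > 20000 nM in this assay, at which 2 of the 3 values shown sit. Within the data shown here, no step to compound 3 can therefore be sized from them.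

Compound 4 `O=C(Nc1cccc(F)c1)c1cc(=O)[nH]c2cc(-c3ccc(F)nc3)ccc12` differs from compound 3 in one place, with 6-fluoropyridin-3-yl in place of 3-fluorophenyl on an aromatic carbon. Among the measured compounds shown here, no measured pair shows what this exchange does in this assay, so no direction is favoured, and the expectation is for no step beyond the scatter. That expectation starts from compound 3 at 12000 nM. The estimated change is a 1.2-fold lower number from compound 3 to compound 4 (0.08 log units; within the scatter). For compound 4 the expected value is 10000 nM, with an estimated range from 3500 nM to 20000 nM.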

Compound 4, half-maximal inhibitory concentration: > 20000 nM
Compound 4: a limit, no number; the forecaster's own chance of this, stated with the estimate: 20%; at least 2.0-fold (0.30 log units) between middle value and limit.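

Putting 6-fluoropyridin-3-yl in place of 3-fluorophenyl on this aromatic carbon gives an at least 1.6-fold higher number from compound 3 to compound 4 (0.22 log units; that floor lies within the scatter) in this assay as the first step measured at this position. Compound 4 gives > 20000 nM as a limit of the assay, not a number. The exchange therefore shows no gain on this read-out, but only a floor is known, which does not by itself separate the two compounds, and the true size of the step stays unread: the limit of > 20000 nM in this assay, at which 3 of the 4 values shown sit.

Going by these compounds, whether an amine or a carboxylic acid on this aromatic carbon would bring the number down remains open. Equally open, on these data alone, is how a pyridine ring without fluorine, or one with a methoxy group in place of that fluorine, would read.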